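From pyrrolidin-1-yl to piperidin-1-yl on compound 2

The source may report more compounds than this note shows. Statements on the series, on what has been measured and on what is new or still open speak of the compounds shown alone.

In a functional assay on ECa-109 cells for inhibition, with ECa-109 cell line (Homo sapiens) as the target, read by sulforhodamine B assay (on this read-out lower numbers stand for stronger inhibition and higher numbers for weaker inhibition), compound 1 (`COc1ccccc1NC1=CC(=O)c2c(nc3n2[C@H]2OC[C@@H](O)[C@H]2OC3)C1=O`) reaches only a limit, > 4000 nM, and no number. Compound 2 (`O=C1C(N2CCCC2)=CC(=O)c2c1nc1n2[C@H]2OC[C@@H](O)[C@H]2OC1`) likewise stands at a limit, > 16000 nM, and no number. In compound 3 (`O=C1C(N2CCCCC2)=CC(=O)c2c1nc1n2[C@H]2OC[C@@H](O)[C@H]2OC1`), piperidin-1-yl replaces pyrrolidin-1-yl (piperidin-1-yl in place of pyrrolidin-1-yl on a double-bonded ring carbon) on a double-bonded ring carbon. Among the measured compounds shown here, the one measured step, a step that the two limits leave unreadable from compound 1 to compound 2, offers no size to carry over, so no clear change in either direction is expected in this assay here. The expected step that the limit leaves unreadable from compound 2 to compound 3 is therefore a loose estimate. Compound 3 is estimated at 20000 nM with an expected range of 6000 nM to 60000 nM and may also return only a limit.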

Compound 3, half-maximal inhibitory concentration: > 8000 nM
Compound 3 ended at the assay's limit; the forecaster's own chance of this, stated with the estimate: 60%; the middle value lies beyond the limit too.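

Among the compounds shown here, compound 1, compound 2 and compound 3 all stand at limits rather than numbers, so no step among them can be read. The compounds shown leave open whether (2-methoxyphenyl)amino, pyrrolidin-1-yl and piperidin-1-yl differ in inhibition at all.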